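From 2,5-difluorobenzyl to isobutyl on a shared core

This account rests on a few compounds, and the source may have more. Where it says the series, first, only, none or still open, it means among the compounds named here.

Of the compounds shown here, three on a shared core have been tested in a functional assay on MCF7 cells (Homo sapiens) for cytotoxicity; on this read-out higher numbers stand for weaker inhibition and lower numbers for stronger inhibition. Compound 1 (`COc1ccc(Cn2nc(Nc3cc(C)[nH]n3)c3ccccc3c2=O)cc1`) reads > 30000 nM, which is a limit of the assay and not a number. Going by the values given here, compound 2 (`Cc1cc(Nc2nn(Cc3cccnc3)c(=O)c3ccccc23)n[nH]1`) gives 13400 nM, the only measured number so far. Compound 3 (`Cc1cc(Nc2nn(Cc3cc(F)ccc3F)c(=O)c3ccccc23)n[nH]1`) reads > 30000 nM, again a limit. Compound 3 therefore sits at the limit of > 30000 nM in this assay, at which 2 of the 3 values shown sit.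

Compound 4 (`Cc1cc(Nc2nn(CC(C)C)c(=O)c3ccccc23)n[nH]1`) has not yet been measured. It carries isopropyl in place of 2,5-difluorophenyl on a saturated chain carbon bound to an aromatic nitrogen, which can also be read as 2,5-difluorobenzyl to isobutyl: isopropyl in place of 2,5-difluorophenyl on a saturated chain carbon bound to an aromatic nitrogen.

Earlier changes at this place gave an at least 2.2-fold lower number from compound 1 to compound 2 (0.35 log units; beyond the scatter) and then an at least 2.2-fold higher number from compound 2 to compound 3 (0.35 log units; beyond the scatter), each at least modest. The remaining pair shows a step that the two limits leave unreadable from compound 1 to compound 3. None of these steps replaces the ring with a small chain, so they offer only a loose guide.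

Because compound 2 gives 13400 nM as the lone number, little movement is expected in this assay, at most a modest shift towards lower numbers. Another limit is quite likely for compound 4. The expected step is an at least 1.2-fold lower number from compound 3 to compound 4 (0.07 log units; that floor lies within the scatter). The estimate for compound 4 is 25000 nM, with an expected range from 11000 nM to 50000 nM.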

Compound 4, half-maximal inhibitory concentration: 4200 nM
The estimate for compound 4 lay 6.0-fold (0.77 log units) above the measured number; measured number below the stated range.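

In this assay, putting isobutyl in place of a benzyl-type group at this position gives the first sizeable move towards stronger inhibition among these compounds: an at least 7.1-fold lower number from compound 3 to compound 4 (0.85 log units; beyond the scatter), and likewise an at least 7.1-fold lower number from compound 1 to compound 4 (0.85 log units; beyond the scatter). Compound 2 is the only other compound with a real number, and the comparison with it gives a 3.2-fold lower number from compound 2 to compound 4 (0.50 log units; beyond the scatter), so among these four compounds an aromatic ring on the saturated chain carbon is not needed for activity, and the one compound without such a ring gives the lowest number. Compound 1 and compound 3 each read as a limit of the assay and not a number, so the true size of their steps to compound 4 stays open and the step between the two of them cannot be read: the limit of > 30000 nM in this assay, at which 2 of the 4 values shown sit.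

With isobutyl as the only group here that has no ring, the compounds shown cannot tell whether the gain comes from losing the ring or from this particular branched chain. A straight butyl chain, a cyclohexylmethyl group or a chain ending in an amine at the same place would help to separate these two readings.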